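Moving the Chlorine on the Benzyl Arm

This account rests on a few compounds, and the source may have more. Where it says the series, first, only, none or still open, it means among the compounds named here.

Compound 2 `O=c1oc2ccccc2n1CC1CCN(Cc2ccccc2Cl)CC1` gives 61 nM in an assay on membranes from liver for displacement of a labelled ligand from Sigma non-opioid intracellular receptor 1 (Rattus norvegicus) (on this read-out higher numbers stand for weaker inhibition and lower numbers for stronger inhibition), and on that read-out it stands highest of the two numbers recorded. Its nearest neighbour is compound 1 `O=c1oc2ccccc2n1CC1CCN(Cc2ccccc2)CC1`, which in this assay gives 3.6 nM. Going by the values given here, the single step recorded between the pair, a 17-fold higher number from compound 1 to compound 2 (1.23 log units; beyond the scatter), is large and lies well beyond the scatter.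

Compound 3 `O=c1oc2ccccc2n1CC1CCN(Cc2ccc(Cl)cc2)CC1` has not yet been measured. It differs from compound 2 by 4-chlorophenyl in place of 2-chlorophenyl on a saturated chain carbon bound to an amine nitrogen in a ring. Among the compounds with values here, no measured step covers this rearrangement directly. The step from compound 1 to compound 2 bears on it only indirectly: it shows that the unsubstituted benzyl of compound 1 gives a much lower number in this assay than the 2-chlorophenyl arrangement, so the question is whether the 4-chlorophenyl arrangement recovers part of that ground. With only two points, the expectation is a return toward compound 1 rather than a further rise. The step expected is a 10-fold lower number from compound 2 to compound 3 (1.01 log units; beyond the scatter), a fall beyond the scatter. Compound 3 is therefore estimated to give 6 nM in this assay, within a range of 1.5 nM to 25 nM.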

Compound 3, inhibition constant: 0.1 nM
The estimate for compound 3 lay 60-fold (1.78 log units) above the measured number; the measured number lies below the stated range.
By their numbers in this assay, from the lowest: compound 3; then compound 1; then compound 2.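

In this assay, the same chlorine on the benzyl arm gives a 610-fold lower number from compound 2 to compound 3 (2.79 log units; beyond the scatter) as 4-chlorophenyl takes the place of 2-chlorophenyl, so at this saturated chain carbon bound to an amine nitrogen in a ring, the place of the chloro on the phenyl ring matters a great deal, although the atoms counted on the two groups are identical. The earlier step could have been read as a penalty for any chloro in place of hydrogen, but the change now runs both ways: against the unsubstituted benzyl of compound 1, the 2-chlorobenzyl arm gives a 17-fold higher number from compound 1 to compound 2 (1.23 log units; beyond the scatter) while the 4-chlorobenzyl arm gives a 36-fold lower number from compound 1 to compound 3 (1.56 log units; beyond the scatter) and leaves compound 3 with the lowest number of the set. No measurement at hand explains why the two chlorobenzyl arms part so widely.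

The three compounds leave open whether this gain belongs to chloro itself or would also appear with a bromo, methyl or methoxy group in its place on the same aromatic carbon. They also leave open whether the wide gap between the 2-chlorobenzyl and 4-chlorobenzyl arms would persist on a core other than the one shared here.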